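The source may report more compounds than this note shows. Statements on the series, on what has been measured and on what is new or still open speak of the compounds shown alone.

Values in a functional assay on cells (Homo sapiens) for cytotoxicity, read by MTT assay, with a stated time of 24 h; a lower number here means a stronger inhibitor, a higher number a weaker inhibitor
compound 1 `CCCCCCCCCCCCCCNC(=O)[C@H](CO)NCc1ccccc1O` gives 75300 nM
compound 2 `CCCCCCCCCCCCCCNC(=O)[C@H](CO)/N=C/c1ccc(Cl)cc1` gives 27500 nM
compound 3 `CCCCCCCCCCCCCCNC(=O)[C@H](CO)NCc1ccccc1[N+](=O)[O-]` gives 29400 nM

In this assay compound 2 stands within the scatter of compound 3, and the numbers of both lie under that of compound 1. Compound 4 `CCCCCCCCCCCCCCNC(=O)[C@H](CO)/N=C/c1ccc(C)cc1` keeps the rest of compound 2 and carries methyl in place of chloro on an aromatic carbon in its structure. Among the measured compounds shown here, two measured steps bear on this only indirectly: a 2.7-fold lower number from compound 1 to compound 2 (0.44 log units; beyond the scatter) and a 2.6-fold lower number from compound 1 to compound 3 (0.41 log units; beyond the scatter) are both modest, and neither exchanges these two groups. No step beyond the scatter is therefore expected in this assay here. The estimate means a 1.1-fold higher number from compound 2 to compound 4 (0.04 log units; within the scatter) as the expected change. Compound 4 is estimated at 30000 nM with an expected range of 15000 nM to 60000 nM for its value.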

Compound 4, half-maximal inhibitory concentration: 102000 nM
Compound 4: middle estimate off by 3.4-fold (0.53 log units), on the low side, outside the stated range (above it).
By their numbers in this assay, from the lowest: compounds 2 and 3 (each within the scatter of the next); then compounds 1 and 4 (each within the scatter of the next).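

In this assay, the position on the aromatic ring, para to a large group, turns out to be sensitive to a swap of one heavy atom for another: methyl in place of chloro gives a 3.7-fold higher number from compound 2 to compound 4 (0.57 log units; beyond the scatter) (beyond the scatter), although neither group has hydrogen-bond donors or acceptors. With methyl, the result is within the scatter of the hydroxy-bearing reference, as a 1.4-fold higher number from compound 1 to compound 4 (0.13 log units; within the scatter) shows, so the lower number of compound 2 is not kept by compound 4. Nothing measured here accounts for the difference between chloro and methyl.

On these data alone, whether fluoro, bromo, methoxy or an amine at this position would follow chloro or methyl remains open. So does whether the change from 4-chlorophenyl to 4-methylphenyl would give a similar step on a shorter chain.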